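A few compounds are considered here, and "the series" means these few. Any claim that something is new, unique, unknown or untested is made for them only; others in the source may bear on it.

In a functional assay on LNCaP cells (Homo sapiens) for cytotoxicity, read by WST assay, with a stated time of 48 h (a higher number here means a weaker inhibitor, a lower number a stronger inhibitor), compound 1 (`COc1ccccc1N1CCN(CCCNC(=O)CCCc2c[nH]c3ccccc23)CC1`) gives 52300 nM and compound 2 (`COc1ccccc1N1CCN(CCCNC(=O)c2cc3ccc(Br)cc3[nH]2)CC1`) gives 26700 nM in the same test, two values within the scatter of each other. Compound 3 (`COc1ccccc1N1CCN(CCCNC(=O)c2cc3cc(Cl)ccc3[nH]2)CC1`), not yet measured, differs from compound 2 on a carbonyl carbon (5-chloro-1H-indol-2-yl in place of 6-bromo-1H-indol-2-yl on a carbonyl carbon), with 5-chloro-1H-indol-2-yl in place of 6-bromo-1H-indol-2-yl. Within the data shown here, no step between measured compounds bears on this swap, so no change beyond the scatter is expected in this assay (a 1.1-fold higher number from compound 2 to compound 3 (0.05 log units; within the scatter)) as the estimated step. Compound 3 is expected at an estimated 30000 nM (12000 nM to 75000 nM).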

Compound 3, half-maximal inhibitory concentration: 28400 nM
Estimate against measurement, compound 3: 1.1-fold (0.02 log units) above; the measured number falls inside the stated range.
By their numbers in this assay, from the lowest: compounds 2, 3 and 1 (each within the scatter of the next).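

In this assay, among these compounds, the change to 5-chloro-1H-indol-2-yl in place of 6-bromo-1H-indol-2-yl on a carbonyl carbon amounts to a 1.1-fold higher number from compound 2 to compound 3 (0.03 log units; within the scatter) and is the first step read between compounds that differ in one place. The swap alters both the halogen and its numbered position, and the two alterations cannot be told apart from this single step. No measurement offered here bears on this result.

As far as these compounds go, what remains open is whether the unsubstituted 1H-indol-2-yl or 5-bromo-1H-indol-2-yl would give a number beyond the scatter. From the compounds shown here alone, an amine or a carboxylic acid at the same ring position is equally open.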